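The source may hold more compounds than are shown below. What is called first, only, known or untested is meant among the compounds shown, and "the series" means these compounds.

Compound 1, `NC(=O)CCCSC[C@H](NC(=O)OCc1ccccc1)C(=O)Nc1ccccc1`: 11%
Compound 2, `O=C(O)CCCNC(=O)CCCSC[C@H](NC(=O)OCc1ccccc1)C(=O)Nc1ccccc1`: 35%
Compound 3, `CCCCCCCCCCCCCNC(=O)CCCSC[C@H](NC(=O)OCc1ccccc1)C(=O)Nc1ccccc1`: 31%

These three compounds share one core and differ only in what sits on the amide-type nitrogen at the end of the chain. In an assay for inhibition of NAD-dependent protein deacylase sirtuin-6 (Homo sapiens), read by HPLC, with stated times of 15 min and 1 h, tested at 333 uM (on this read-out higher numbers stand for more inhibition at the one concentration tested (going by the name of the read-out) and lower numbers for less inhibition), compound 1 gives 11%, compound 2 gives 35% and compound 3 gives 31%. Compound 3 thus stands second highest of the three numbers, with compound 2 nearest and within the scatter, and compound 1 furthest and beyond it.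

Compound 4, `CCCCCCCCNC(=O)CCCSC[C@H](NC(=O)OCc1ccccc1)C(=O)Nc1ccccc1`, has not yet been measured. It differs from compound 3 by hydrogen in place of pentyl on a saturated chain carbon, eight bonds along the chain from an amide-type nitrogen.

Going by the values given here, two measured steps bear on this change. The step of a number 24 percentage points higher from compound 1 to compound 2 (beyond the scatter) shows that attaching a group to the amide-type nitrogen raises inhibition, whereas a number 4 percentage points lower from compound 2 to compound 3 (within the scatter) shows that exchanging carboxy for decyl at the far end of that group changes little. Since compound 4 keeps a long chain on the nitrogen, the expected change in this assay is a number 2 percentage points lower from compound 3 to compound 4 (within the scatter), nothing beyond the scatter. Compound 4 is therefore estimated at 29%, with a range from 16% to 42%.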

Compound 4, a percentage reported as inhibition, at one concentration (the size of the read-out at that concentration, not a potency): "not active" (no number reported)
Compound 4 has no reported number here, so the estimate cannot be set against anything.
By their numbers in this assay, from the lowest: compound 1; then compounds 3 and 2 (each within the scatter of the next).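

Going by these compounds alone, compound 4 is reported as not active, without a number, so no step from compound 3 to compound 4 can be read. The compounds shown leave open how inhibition changes with the length of the chain on the nitrogen. Nothing measured here explains this result.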